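The source may report more compounds than this note shows. Statements on the series, on what has been measured and on what is new or still open speak of the compounds shown alone.

Measured compounds:
- Compound 1 `Cc1nc(C)n(CC(=O)N2CCN(c3sc(C(F)(F)F)nc3-c3nc4c(F)cccc4[nH]3)C[C@H]2C)n1`: 3.1 nM
- Compound 2 `Cc1nc(C)n(CC(=O)N2CCN(c3sc(C(F)(F)F)nc3-c3nc4ccccc4[nH]3)C[C@H]2C)n1`: 3.2 nM

In a functional assay on CHO-K1 cells for antagonist activity at C-X-C chemokine receptor type 3 (Homo sapiens), read by FLIPR, with a stated time of 10 min, in the presence of a further agent that is not named here (a lower number here means a stronger inhibitor, a higher number a weaker inhibitor), compound 2 gives 3.2 nM, and compound 1 gives 3.1 nM; the two values lie within the scatter of one another. Going by the values given here, the one measured step, a 1.0-fold higher number from compound 1 to compound 2 (0.01 log units; within the scatter), bears on the position in question: hydrogen in place of fluoro left the number unchanged. Compound 3 `Cc1nc(C)n(CC(=O)N2CCN(c3sc(C(F)(F)F)nc3-c3nc4c(C(F)(F)F)cccc4[nH]3)C[C@H]2C)n1` carries trifluoromethyl in place of hydrogen on an aromatic carbon. Among the compounds with values here, the step from fluoro to hydrogen cost nothing, but no step adds a group of this size at that carbon, so the expected change for compound 3 is a 1.9-fold higher number from compound 2 to compound 3 (0.27 log units; within the scatter), a modest weakening at most. Compound 3 is estimated at 6 nM (range 2 nM to 25 nM).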

Compound 3, half-maximal inhibitory concentration: 6 nM
For compound 3 middle estimate and measured number coincide at the digits printed; low and high end bracket the measured number.
By their numbers in this assay, from the lowest: compounds 1, 2 and 3 (each within the scatter of the next).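

Hydrogen to trifluoromethyl gives a 1.9-fold higher number from compound 2 to compound 3 (0.27 log units; within the scatter) and fluoro to trifluoromethyl gives a 1.9-fold higher number from compound 1 to compound 3 (0.29 log units; within the scatter) so this aromatic carbon accepts a group of 4 heavy atoms with no step beyond the scatter. Hydrogen, fluoro and trifluoromethyl at this carbon therefore cannot be told apart by these numbers.

From the compounds shown here alone, whether an amine, a carboxylic acid or a methoxy group at this carbon would keep the number in the same range stays open. Nothing available here explains this tolerance.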